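The source may report more compounds than this note shows. Statements on the series, on what has been measured and on what is new or still open speak of the compounds shown alone.

In an ADME assay on Vero cells (Chlorocebus sabaeus) for cytotoxicity, read by MTT assay, with a stated time of 96 h (on this read-out higher numbers stand for lower toxicity in this test and lower numbers for higher toxicity in this test), compound 1 (`C/C(=N\NC(N)=O)c1ccc2[nH]c(-c3ccccc3)nc2c1`) gives > 100000 nM as its result, which is a limit of the assay and not a number. Compound 2 (`C/C(=N\NC(N)=O)c1ccc2c(c1)nc(-c1ccoc1)n2C1CCCCC1`) has "not determined" (no result reported) as its entry, so it stands without any number of its own in this test. Compound 3 (`C/C(=N\NC(N)=O)c1ccc2[nH]c(-c3ccoc3)nc2c1`) comes from compound 2 by the change hydrogen in place of cyclohexyl on an aromatic nitrogen with hydrogen in place of cyclohexyl on an aromatic nitrogen. For the measured compounds named here, no measured step bears on this change, and no step beyond the usual scatter is expected in this assay for it. Going by the values given here, the expectation rests on compound 1 alone and on the limit of > 100000 nM in this assay, at which 1 of the 2 values shown sits, as its only guide, and that figure is a limit. For compound 3 the estimated half-maximal cytotoxic concentration is 100000 nM with an expected range from 40000 nM to 200000 nM in this estimate.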

Compound 3, half-maximal cytotoxic concentration: > 100000 nM
Compound 3 ended at the assay's limit; the forecaster's own chance of this, stated with the estimate: 75%; the middle value lies on the limit itself.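

For the compounds shown here, compound 1 and compound 3 both end at a limit in this assay, so no step between them can be read: the limit of > 100000 nM in this assay, at which 2 of the 3 values shown sit.

The compounds shown leave open what furan-3-yl in place of phenyl does to this read-out, and what cyclohexyl on the aromatic nitrogen does.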